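The source may hold more compounds than are shown below. What is called first, only, known or untested is meant among the compounds shown, and "the series" means these compounds.

Measured so far:
- compound 1, `COc1cc(-c2cc(/C=C/C(=O)c3ccc(N)cc3)[nH]n2)cc(OC)c1OC`: 5100 nM in a functional assay on NCI-H460 cells (Homo sapiens) for inhibition, read by sulforhodamine B assay, with a stated time of 48 h; on this read-out higher numbers stand for weaker inhibition of growth and lower numbers for stronger inhibition of growth
- compound 2, `COc1ccc(-c2cc(/C=C/C(=O)c3ccc(OC)c(OC)c3)[nH]n2)cc1`: 4340 nM
- compound 3, `COc1cc(-c2cc(/C=C/C(=O)c3ccc(Cl)c(Cl)c3)[nH]n2)cc(OC)c1OC`: 36600 nM

Among these three, compound 1 stands second highest. Its nearest neighbour is compound 2, whose number lies within the scatter of repeated measurements, so the two cannot be told apart. Going by the values given here, the furthest is compound 3, reached by the one single-point step known here: a 7.2-fold higher number from compound 1 to compound 3 (0.86 log units; beyond the scatter). That step alters the ring attached to the carbonyl carbon and says nothing about the other ring of the shared core.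

Compound 4, `COc1ccc(-c2cc(/C=C/C(=O)c3ccc(N)cc3)[nH]n2)cc1OC`, differs from compound 1 at that other ring: hydrogen in place of methoxy on an aromatic carbon. Among the compounds with values here, no measured pair shows what removing a methoxy group from this ring does. Compound 2 also carries fewer methoxy groups on this ring than compound 1, but it differs from compound 1 on the carbonyl-side ring as well, so its value cannot be read as a single change. Within the data shown here, with no step bearing directly on this change, the expectation for this assay is no step beyond the scatter, in either direction, and the estimate is built around compound 1 with a wide range.

For compound 4 the expected value is 5000 nM, with a range from 1500 nM to 17000 nM. The expected step is a 1.0-fold lower number from compound 1 to compound 4 (0.01 log units; within the scatter).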

Compound 4, concentration for total growth inhibition: 4530 nM
The estimate for compound 4 lay 1.1-fold (0.04 log units) above the measured number, and the stated range covers the measured number.
By their numbers in this assay, from the lowest: compounds 2, 4 and 1 (each within the scatter of the next); then compound 3.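

Hydrogen in place of methoxy on this aromatic carbon, ortho to a methoxy group, gives a 1.1-fold lower number from compound 1 to compound 4 (0.05 log units; within the scatter) in this assay. Going by these compounds alone, this is the first direct reading of this change, which compound 2 could not give since it differs from compound 1 in more than one place, and it shows that, with the 4-aminophenyl group on the carbonyl carbon, this methoxy group can be exchanged for hydrogen with no difference that can be told from the usual scatter of repeated measurements. No measurement here offers an explanation for this result.

The compounds shown leave open whether this position would stay just as undemanding with a different group on it, such as a hydroxyl group, a fluorine atom or an amine, since hydrogen and methoxy are the only two groups seen here. They also leave open whether the same exchange would give a similar result with the 3,4-dichlorophenyl group of compound 3 on the carbonyl carbon, where the number is already higher than for compound 1.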